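This account rests on a few compounds, and the source may have more. Where it says the series, first, only, none or still open, it means among the compounds named here.

In an ADME assay on microsomes from liver (Canis lupus familiaris) for metabolic stability (a lower number here means that the compound disappears faster, a higher number that the compound lasts longer), compound 1 `Clc1ccc(-c2nc(NCCNc3ccccn3)ncc2-c2ncc[nH]2)c(Cl)c1` gives > 0.5 h, which is a limit of the assay and not a number. Compound 2 `Nc1nc(NCCNc2ncc(-c3ncc[nH]3)c(-c3ccc(Cl)cc3)n2)ccc1[N+](=O)[O-]` gives > 0.5 h, also only a limit. This is the limit of > 0.5 h in this assay, at which 2 of the 2 values shown sit, so compound 2 has no exact standing. Compound 3 `Nc1nc(NCCNc2ncc(-c3ncc[nH]3)c(-c3ccccc3Cl)n2)ccc1[N+](=O)[O-]` carries 2-chlorophenyl in place of 4-chlorophenyl on an aromatic carbon. Among the measured compounds shown here, no measured step between compounds informs this change, so no shift beyond the scatter is expected in this assay. The expected step that the limit leaves unreadable from compound 2 to compound 3 therefore has no firm direction. Compound 3 is estimated at 0.7 h, with an expected range of 0.35 h to 1.4 h.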

Compound 3, half-life: > 0.5 h
Compound 3 ended at the assay's limit (the forecaster's own chance of this, stated with the estimate: 65%); the middle value lies beyond the limit too.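

No step from compound 2 to compound 3 can be read in this assay, because both values are limits of the assay and not numbers: the limit of > 0.5 h in this assay, at which 3 of the 3 values shown sit.

The compounds shown leave open whether 2-chlorophenyl in place of 4-chlorophenyl changes the half-life at all.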